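Configuration swap at two ring carbons: compound 3 assessed

The source may hold more compounds than are shown below. What is called first, only, known or untested is meant among the compounds shown, and "the series" means these compounds.

Among the measured compounds shown here, compound 2 `C[C@]1(O)C[C@@](c2ccc(C(F)(F)F)cc2)([C@H](O)c2ccccn2)C1` stands with the lowest of the two numbers measured so far in an assay on HEK293 cells for antagonist activity at transient receptor potential cation channel subfamily V member 3 (Homo sapiens), read by FLIPR and calcium flux (on this read-out higher numbers stand for weaker inhibition and lower numbers for stronger inhibition), where compound 2 gives 840 nM. For the measured compounds named here, its only measured neighbour, compound 1 `O[C@H](c1ccccn1)[C@]1(c2ccc(C(F)(F)F)cc2)C[C@@H](O)C1`, gives 1870 nM in this assay, and the step of a 2.2-fold lower number from compound 1 to compound 2 (0.35 log units; beyond the scatter) is the single measured step, coming from a methyl in place of hydrogen on a saturated ring carbon. Compound 3 `C[C@]1(O)C[C@](c2ccc(C(F)(F)F)cc2)([C@H](O)c2ccccn2)C1` is the next compound to be measured. Compared with compound 2, (the two compounds have the same atoms and bonds and differ only in configuration as drawn: 2 of 3 stereo elements differ; a stereocentre at a saturated ring carbon is drawn R in compound 2 and S in compound 3; a stereocentre at a saturated ring carbon is drawn s in compound 2 and r in compound 3). Going by the values given here, no measured step bears directly on this kind of change: the step of a 2.2-fold lower number from compound 1 to compound 2 (0.35 log units; beyond the scatter) concerns an added methyl and not a change of configuration, so it offers no guide to either size or direction. Among the compounds with values here, the measured compounds give no precedent for swapping configuration at two ring carbons, so a change in either direction, or none beyond the scatter, remains possible. On balance compound 3 is expected to show a 1.8-fold higher number from compound 2 to compound 3 (0.25 log units; within the scatter) in this assay. Compound 3 is therefore estimated at 1500 nM in this assay, with a range from 400 nM to 6000 nM.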

Compound 3, antagonist equilibrium constant: 4790 nM
Beside the measured number, compound 3's estimate is 3.2-fold (0.50 log units) below it, and the stated range covers the measured number.
By their numbers in this assay, from the lowest: compound 2; then compound 1; then compound 3.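

In this assay, the series now shows a 5.7-fold higher number from compound 2 to compound 3 (0.76 log units; beyond the scatter), so configuration at these two ring carbons moves the number on its own, and here the move is towards weaker inhibition. Among the compounds shown here, this shift is larger than the only other measured step, a 2.2-fold lower number from compound 1 to compound 2 (0.35 log units; beyond the scatter), so in this pair of compounds the drawn arrangement at the ring carbons counts for more than the added methyl did in the earlier pair. The shift can be put down to configuration alone because no atom or bond changes: the fact that compounds 2 and 3 differ only in the configuration as drawn

Both stereocentres change together from compound 2 to compound 3, so the compounds shown cannot say whether one of them carries the shift or both contribute. They also leave open whether the same preference for the arrangement in compound 2 would hold with an ethyl group in place of the methyl, or with an amine in place of the hydroxyl on that saturated ring carbon.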